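The compounds below may be only part of what the source reports. "The series", "measured", "known", "first", "only" and "open" are said of these compounds alone.

Compound 1 `O=C(/C=C/c1ccc(O)cc1)c1c(O)cccc1OCCC1CCCC1`: 3340 nM
Compound 2 `CC(C)(C)CCOc1cccc(O)c1C(=O)/C=C/c1ccc(O)cc1`: 2380 nM
Compound 3 `CC(C)CCOc1cccc(O)c1C(=O)/C=C/c1ccc(O)cc1`: 10300 nM

Within the data shown here, these are the three compounds measured so far in a functional assay on MDA-MB-231 cells (Homo sapiens) for antiproliferative activity, read by sulforhodamine B assay; on this read-out higher numbers stand for weaker inhibition of growth and lower numbers for stronger inhibition of growth. Compound 3 has the highest number of the three, as a 3.1-fold higher number from compound 1 to compound 3 (0.49 log units; beyond the scatter) and a 4.3-fold higher number from compound 2 to compound 3 (0.64 log units; beyond the scatter) show, whereas a 1.4-fold lower number from compound 1 to compound 2 (0.15 log units; within the scatter).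

Compound 4 `CC(C)COc1cccc(O)c1C(=O)/C=C/c1ccc(O)cc1` differs from compound 3 in one place: isopropyl in place of isobutyl on a saturated chain carbon bound to an oxygen on an aromatic ring. Among the measured compounds shown here, no measured step shortens the chain; the two steps that lead into compound 3 alter the branching at the end of the chain, and both raise the number. For the measured compounds named here, nothing among the measured steps points to a direction for this change, so a 1.1-fold higher number from compound 3 to compound 4 (0.03 log units; within the scatter) is expected to stay within the scatter. Compound 4 is therefore estimated at 11000 nM, with a range from 4500 nM to 27000 nM.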

Compound 4, concentration for 50% growth inhibition: 3520 nM
Compound 4: the middle estimate sits 3.1-fold (0.49 log units) above what was measured; the whole stated range lies above it.
By their numbers in this assay, from the lowest: compounds 2, 1 and 4 (each within the scatter of the next); then compound 3.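

In this assay the cut from isopentyloxy to isobutoxy is no silent change: it gives a 2.9-fold lower number from compound 3 to compound 4 (0.47 log units; beyond the scatter) and leaves compound 3 alone with the weakest growth inhibition of the four. With a 1.5-fold higher number from compound 2 to compound 4 (0.17 log units; within the scatter) and a 1.1-fold higher number from compound 1 to compound 4 (0.02 log units; within the scatter) on the saturated chain carbon bound to an oxygen on an aromatic ring, isobutyl, neopentyl and cyclopentylmethyl sit together, and only compound 3 goes against that pattern. No measurement shown here accounts for this step.

From the compounds shown here alone, whether an ethyl group or a longer chain such as hexyl would stay level with compound 4 remains open. So does the effect of an amine or a carboxylic acid at the end of the chain.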